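Lengthening the Amide Chain of a Furoyl Threonine Amide

The compounds below may be only part of what the source reports. "The series", "measured", "known", "first", "only" and "open" are said of these compounds alone.

Of the compounds shown here, three sharing one core have been tested in a functional assay on SiHa cells (Homo sapiens) for cytotoxicity, read by MTT assay, with a stated time of 48 h; on this read-out lower numbers stand for stronger inhibition and higher numbers for weaker inhibition. Compound 1 `CCCCCCCCNC(=O)[C@@H](NC(=O)c1ccco1)[C@@H](C)O` gives 124000 nM, the highest of the three numbers. Compound 2 `CCCCCCCCNC(=O)[C@@H](NC(=O)c1cc2ccccc2o1)[C@@H](C)O` gives 66500 nM, and compound 3 `CCCCCCCCNC(=O)[C@@H](NC(=O)/C=C/c1ccccc1)[C@@H](C)O` gives 41400 nM. Every measured step among these three swaps the group on the carbonyl carbon: a 1.9-fold lower number from compound 1 to compound 2 (0.27 log units; within the scatter), a 3.0-fold lower number from compound 1 to compound 3 (0.48 log units; beyond the scatter), and a 1.6-fold lower number from compound 2 to compound 3 (0.21 log units; within the scatter).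

Compound 4 `CCCCCCCCCCCCNC(=O)[C@@H](NC(=O)c1ccco1)[C@@H](C)O` differs from compound 1 in a different place: butyl in place of hydrogen on a saturated chain carbon, eight bonds along the chain from an amide-type nitrogen. Among the compounds with values here, none of the measured steps touches that chain, so nothing in the data speaks directly to this change. What the three measured steps do show is that single changes in this series move the numbers only a little, from within the scatter to modest. For compound 4, therefore, a step within the scatter or at most a modest lowering of the number is expected, and the estimated step is a 1.6-fold lower number from compound 1 to compound 4 (0.19 log units; within the scatter). Compound 4 is expected to give 80000 nM in this assay, with a range from 25000 nM to 250000 nM.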

Compound 4, half-maximal inhibitory concentration: 64300 nM
Beside the measured number, compound 4's estimate is 1.2-fold (0.09 log units) above it; measured number inside the range.
By their numbers in this assay, from the lowest: compounds 3, 4, 2 and 1 (each within the scatter of the next, the first and the last beyond it).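

In this assay, within the data shown here, this is the first reading at this position: butyl in place of hydrogen on a saturated chain carbon, eight bonds along the chain from an amide-type nitrogen, gives a 1.9-fold lower number from compound 1 to compound 4 (0.29 log units; within the scatter). The step adds 4 carbon atoms, yet compound 1 and compound 4 cannot be told apart in this assay, so this one added length on the chain shows no clear effect on the number. Nothing available here bears on why the step has this size.

The compounds shown leave open whether a chain longer than that of compound 4, or one shorter than that of compound 1, would give a step beyond the scatter, and what an amine or a carboxylic acid on this chain would do. They also leave open whether butyl in the same place would give a step of similar size in compounds that carry the 1-benzofuran-2-yl group of compound 2 or the 2-phenylethenyl group of compound 3 on the carbonyl carbon.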